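The compounds below may be only part of what the source reports. "The series", "measured", "known", "first", "only" and "open" are said of these compounds alone.

Compound 1 `Nc1ccc(-c2cc(=O)c3c(N)cccc3o2)cc1`: 210 nM
Compound 2 `Nc1ccc(-c2cc(=O)c3c(N)ccc(O)c3o2)cc1`: 16000 nM

In a functional assay on MCF7 cells (Homo sapiens) for inhibition, in the presence of a further agent that is not named here (a lower number here means a stronger inhibitor, a higher number a weaker inhibitor), compound 2 has the higher of the two numbers, which makes it the weaker inhibitor of the pair. Among the compounds with values here, only one measured step bears on what comes next: a 76-fold higher number from compound 1 to compound 2 (1.88 log units; beyond the scatter), a large step that came with hydroxy in place of hydrogen on an aromatic carbon. Compound 3 `Nc1ccc(-c2cc(=O)c3c(N)ccc(Cl)c3o2)cc1` changes that same carbon: chloro in place of hydroxy on an aromatic carbon. This is chloro in place of hydroxy, para to an amino group. Within the data shown here, no chloro compound has been measured, so the guide is thin. With the hydroxy gone, a sizeable move toward a lower number is expected in this assay, though perhaps not all the way back to compound 1. The expected move is an 11-fold lower number from compound 2 to compound 3 (1.03 log units; beyond the scatter). For compound 3 the estimated value is 1500 nM, within a range of 200 nM to 10000 nM.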

Compound 3, half-maximal inhibitory concentration: 250 nM
Beside the measured number, compound 3's estimate is 6.0-fold (0.78 log units) above it; the range from low to high includes it.
By their numbers in this assay, from the lowest: compounds 1 and 3 (each within the scatter of the next); then compound 2.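

In this assay, the large loss seen with hydroxy at this carbon does not follow every replacement of hydrogen: chloro in place of hydroxy gives a 64-fold lower number from compound 2 to compound 3 (1.81 log units; beyond the scatter) and chloro in place of hydrogen gives a 1.2-fold higher number from compound 1 to compound 3 (0.08 log units; within the scatter) in the same test. This carbon, para to an amino group, can therefore carry a chloro group with no difference beyond the scatter, so among these three compounds the loss goes with hydroxy, not with simply having a group other than hydrogen there. Nothing at hand explains why these two groups differ so widely. Going by these compounds, whether fluoro, methyl or methoxy at this carbon would behave like chloro or like hydroxy remains open. So does the effect of a larger group there, such as a carboxylic acid.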